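A few compounds are considered here, and "the series" means these few. Any claim that something is new, unique, unknown or untested is made for them only; others in the source may bear on it.

Working notes on the series. For the measured compounds named here, in a functional assay on MCF7 cells (Homo sapiens) for antiproliferative activity, read by MTT assay, with a stated time of 48 h (on this read-out higher numbers stand for weaker inhibition and lower numbers for stronger inhibition), compound 2 `O=C(/C=C/c1ccncc1)c1nc2ccccc2[nH]1` gives 20900 nM, the only actual number obtained so far. Compound 1 `O=C(/C=C/c1ccccn1)c1nc2ccccc2s1` reads > 100000 nM, which is a limit of the assay and not a number. Compound 3 `COc1cccc(/C=C/C(=O)c2nc3ccccc3o2)c1` reads > 100000 nM, again a limit of the assay. The series therefore offers one numeric value and two limits, summed up as the limit of > 100000 nM in this assay, at which 2 of the 3 values shown sit. Going by the values given here, no two measured compounds differ in one place, so the series gives no direct measure of what a single change does.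

The next compound is compound 4 `O=C(/C=C/c1cccnc1)c1nc2ccccc2[nH]1`, which has the same atoms as compound 2, joined differently: pyridin-3-yl in place of pyridin-4-yl on a double-bonded chain carbon bound to a double-bonded chain carbon. In words, pyridin-3-yl stands in place of pyridin-4-yl on a double-bonded chain carbon bound to a double-bonded chain carbon.

Among the compounds with values here, with no measured step to go by, no step beyond the scatter is expected in this assay, and no direction is favoured with any confidence. The expectation rests on compound 2 at 20900 nM as its sole anchor. The step expected is a 1.4-fold higher number from compound 2 to compound 4 (0.16 log units; within the scatter). For compound 4 the estimate is 30000 nM, with an expected range of 10000 nM to 90000 nM.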

Compound 4, half-maximal inhibitory concentration: 21700 nM
The estimate for compound 4 lay 1.4-fold (0.14 log units) above the measured number; low and high end bracket the measured number.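

The series now holds its first step at a single place: in this assay, pyridin-3-yl in place of pyridin-4-yl on a double-bonded chain carbon bound to a double-bonded chain carbon gives a 1.0-fold higher number from compound 2 to compound 4 (0.02 log units; within the scatter). At this place, then, the exchange between these two rings with the same atoms leaves the read-out within the scatter, and the two compounds cannot be ranked against each other. Nothing measured here speaks to a cause for this result, so the step stands as an observation only.

Still open, as far as these compounds go, is whether a different group at this place, such as a phenyl ring carrying an amine or a carboxylic acid, would shift the number beyond the scatter, and whether the same ring exchange would read alike on the cores of compound 1 and compound 3. The other readings offer no numeric anchor for either question, as they are limits of the assay and not numbers: the limit of > 100000 nM in this assay, at which 2 of the 4 values shown sit.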